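The compounds below may be only part of what the source reports. "The series", "measured", "known", "first", "only" and "open" are said of these compounds alone.

Compound 1 `CCOC(=O)CCCCCOc1cccc(CN(C(=O)c2ccc(-c3cccc(N(C)C)c3)cc2)C(C)C)c1`: in an ADME assay on Raji cells (Homo sapiens) for cytotoxicity, read by CellTiter-Glo and resazurin assay, with a stated time of 72 h (a lower number here means that less compound is needed, a higher number that more compound is needed for the effect), compound 1 gives > 26000 nM, which is a limit of the assay rather than a number.
Compound 2 `CCOC(=O)CCCCCOc1cccc(CN(C(=O)c2ccc(-c3cccnc3)cc2)C(C)C)c1`: in this assay compound 2 gives > 26000 nM, again a limit.
Compound 3 `CCOC(=O)CCCCCOc1cccc(CN(C(=O)c2ccc(-c3ccc(C(C)=O)s3)cc2)C(C)C)c1`: in this assay compound 3 gives > 26000 nM, also a limit.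

Within the data shown here, compound 3 therefore stands at the edge of what this assay can report, and it shares that position with every other compound measured so far, since (the limit of > 26000 nM in this assay, at which 3 of the 3 values shown sit). The steps that lead into compound 3 give no usable size: a step that the two limits leave unreadable from compound 1 to compound 3, and a step that the two limits leave unreadable from compound 2 to compound 3; the step between the other two, a step that the two limits leave unreadable from compound 1 to compound 2, is equally silent. None of the three exchanges at the aromatic carbon has moved a compound into the measurable range.

The step to compound 4 `CCOC(=O)CCCCCOc1cccc(CN(C(=O)c2ccc(-c3ccc4c(c3)OCCO4)cc2)C(C)C)c1` is another exchange at the same place: 2,3-dihydro-1,4-benzodioxin-6-yl in place of 5-acetylthiophen-2-yl on an aromatic carbon. All measured steps at this position bear on it, and all were unreadable, so nothing in the data points to a shift beyond the scatter in this assay in either direction. The expected outcome is that compound 4 again reports a limit. On that basis compound 4 is expected to give 30000 nM, with a range from 10000 nM to 100000 nM. The estimated step that the limit leaves unreadable from compound 3 to compound 4 is expected to lie within the scatter.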

Compound 4, half-maximal effective concentration: > 24400 nM
Compound 4 gave a limit, no number; the forecaster's own chance of this, stated with the estimate: 85%; the middle value does not contradict the limit.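

Compound 4, like compound 1, compound 2 and compound 3, reports only a limit in this assay, so none of the steps from those three compounds to compound 4 can be read. The compounds shown leave open whether any exchange at this aromatic carbon brings a compound into the measurable range.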